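Replacing a dimethylamino tail with a hydroxymethyl tail

The compounds below may be only part of what the source reports. "The series", "measured", "known", "first", "only" and "open" are said of these compounds alone.

Compound 1 `CC1(C)CC(N)=Nc2ccc(Cl)cc21`: 80.5% in a functional assay on MDA-MB-231 cells (Homo sapiens) for cytotoxicity, read by MTT assay, with a stated time of 72 h, tested at 1 uM, in the absence of a further agent; a higher number here means a weaker effect of the compound at the concentration tested, a lower number a stronger effect
Compound 2 `CNC1=Nc2ccc(Cl)cc2C(C)(C)C1`: 91.9% in this assay
Compound 3 `CN(C)CCNC1=Nc2ccc(Cl)cc2C(C)(C)C1`: 66.9% in this assay

Among these three, compound 3 gives the lowest number, meaning the strongest effect. The nearest to it is compound 1, which lies a number 13.6 percentage points lower from compound 1 to compound 3 (beyond the scatter); the furthest is compound 2, which lies a number 25 percentage points lower from compound 2 to compound 3 (beyond the scatter). Both steps are beyond the scatter but modest in size.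

Compound 4 `CC1(C)CC(NCCCO)=Nc2ccc(Cl)cc21` differs from compound 3 in one place: hydroxymethyl in place of dimethylamino on a saturated chain carbon, two bonds along the chain from an amine nitrogen. Among the compounds with values here, no measured pair shows this exact exchange. Within the data shown here, the steps that bear on it are those that put the dimethylamino-bearing chain in place, since both of them moved the number downward to the value of compound 3: a number 13.6 percentage points lower from compound 1 to compound 3 (beyond the scatter) and a number 25 percentage points lower from compound 2 to compound 3 (beyond the scatter). Compound 4 keeps a chain on the amine nitrogen, so it should not return to the value of compound 2, but it loses the dimethylamino group that accompanied the lowest number. The expectation is therefore a step upward, of a modest size comparable to those steps, namely the estimated a number 11.1 percentage points higher from compound 3 to compound 4 (beyond the scatter). Compound 4 is estimated to give 78% in this assay, with a range from 62% to 94%.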

Compound 4, a percentage reported as activity, at one concentration (the size of the read-out at that concentration, not a potency): 84.5%
For compound 4 the middle estimate is 6.5 percentage points below the measured one; low and high end bracket the measured number.
By their numbers in this assay, from the lowest: compound 3; then compounds 1, 4 and 2 (each within the scatter of the next, the first and the last beyond it).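

In this assay, exchanging the dimethylamino group at the end of the chain for hydroxymethyl gives a number 17.6 percentage points higher from compound 3 to compound 4 (beyond the scatter), so a chain on the amine nitrogen is not enough on its own to give the low number of compound 3; what stands at its end matters. The hydroxyl-ended chain also gives no change that can be separated from the scatter when it replaces the hydrogen on the amine nitrogen, with a number 4 percentage points higher from compound 1 to compound 4 (within the scatter), or when compared with the methyl compound, with a number 7.4 percentage points lower from compound 2 to compound 4 (within the scatter). The data shown offer no explanation for why the dimethylamino end differs from the hydroxyl end.

As far as these compounds go, it remains open whether the lower number needs dimethylamino specifically or would also appear with another amine at the chain end, such as a primary amine or a morpholine ring, and how a carboxylic acid there would compare. From the compounds shown here alone, a longer chain carrying dimethylamino is also open, as is whether the gap seen at this one concentration would hold at other concentrations.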